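Benzyl-ring substitution in a pyridinylamide series: a chlorohexyloxy step

The source may report more compounds than this note shows. Statements on the series, on what has been measured and on what is new or still open speak of the compounds shown alone.

Compound 1 `O=C(Nc1cccnc1)c1ccccc1OCc1ccccc1` gives 3200 nM in an assay on lysate for inhibition of phosphatidylcholine:ceramide cholinephosphotransferase 2 (Homo sapiens), read by HPLC, with stated times of 30 min and 2 h (on this read-out lower numbers stand for stronger inhibition and higher numbers for weaker inhibition), the highest of the three numbers measured, though every step from it lies within the scatter. Compound 2 `O=C(Nc1cccnc1)c1ccccc1OCc1cccc(F)c1` gives 1600 nM and compound 3 `O=C(Nc1cccnc1)c1ccccc1OCc1cccc(Cl)c1F` gives 3100 nM; the steps of a 2.0-fold lower number from compound 1 to compound 2 (0.30 log units; within the scatter), a 1.0-fold lower number from compound 1 to compound 3 (0.01 log units; within the scatter) and a 1.9-fold higher number from compound 2 to compound 3 (0.29 log units; within the scatter) are all within the scatter. Compound 4 `O=C(Nc1cccnc1)c1ccccc1OCc1ccccc1OCCCCCCCl` differs from compound 1 by (6-chlorohexyl)oxy in place of hydrogen on an aromatic carbon. For the measured compounds named here, no measured step covers an alkoxy chain at this place; the halogen steps on the same ring were all small, so no change beyond the scatter is expected, with a wide range given the larger group. The estimate for compound 4 is 3000 nM (range 800 nM to 12000 nM), a step of a 1.1-fold lower number from compound 1 to compound 4 (0.03 log units; within the scatter).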

Compound 4, half-maximal inhibitory concentration: 470 nM
Estimate against measurement, compound 4: 6.4-fold (0.81 log units) above; measured number below the stated range.
By their numbers in this assay, from the lowest: compound 4; then compounds 2, 3 and 1 (each within the scatter of the next).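

For the compounds shown here, the (6-chlorohexyl)oxy group gives the first step in this set that lies beyond the scatter in this assay (a 6.8-fold lower number from compound 1 to compound 4 (0.83 log units; beyond the scatter)). This aromatic carbon, ortho to a large group, therefore accepts a far larger substituent than the halogens of compound 2 and compound 3, and the number falls. Nothing measured here bears on why.

On these data alone, whether the step belongs to the chain, its terminal chlorine or the ether oxygen stays open. A plain hexyloxy group, a shorter butoxy chain or a terminal amine would separate these.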